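This account rests on a few compounds, and the source may have more. Where it says the series, first, only, none or still open, it means among the compounds named here.

Compound 1, `CNCc1cn(S(=O)(=O)c2ccc(OC)cn2)c(-c2cccnc2F)c1F`, gives 95% in a functional assay on the whole organism (strain Jcl:Sprague-Dawley) for inhibition, with Rattus norvegicus as the target, with stated times of 3 min and 3 h, at a dose of 1 mg/kg by the intravenous route; on this read-out higher numbers stand for more inhibition at the one dose given (going by the name of the read-out) and lower numbers for less inhibition.
Compound 2, `CNCc1cn(S(=O)(=O)c2ncccc2C)c(-c2cccnc2F)c1F`, gives 54%.
Compound 3, `CNCc1cn(S(=O)(=O)c2ccc(F)cn2)c(-c2cccnc2F)c1F`, gives 87%.

All three share one core and differ only in the ring carried on the sulfonyl sulfur. Compound 3 stands second highest of the three numbers: its value lies within the scatter of that of compound 1, but well clear of that of compound 2. The measured steps show that a change of the ring on the sulfonyl sulfur can matter a great deal: a number 41 percentage points lower from compound 1 to compound 2 (beyond the scatter), and a number 33 percentage points higher from compound 2 to compound 3 (beyond the scatter). By contrast, a number 8 percentage points lower from compound 1 to compound 3 (within the scatter), so exchanging one small group for another on that ring left the read-out essentially unchanged.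

Compound 4, `CNCc1cn(S(=O)(=O)c2cncc(F)c2)c(-c2cccnc2F)c1F`, has not yet been measured in this assay. It differs from compound 3 by 5-fluoropyridin-3-yl in place of 5-fluoropyridin-2-yl on a sulfonyl sulfur. The ring keeps the same atoms, joined differently. Among the compounds with values here, no measured step shows exactly this kind of change. The two large steps involving compound 2 show that altering the ring on the sulfonyl sulfur can lower inhibition sharply, while the step from compound 1 to compound 3 shows that a milder alteration need not. A drop of uncertain size is therefore expected. Compound 4 is estimated at 65%, within 35% to 90%, which means a number 22 percentage points lower from compound 3 to compound 4 (beyond the scatter).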

Compound 4, a percentage reported as inhibition, in the whole organism at one dose (the size of the read-out at that dose, not a potency): 99%
Beside the measured number, compound 4's estimate is 34 percentage points below it; measured number outside the range, above it.
By their numbers in this assay, from the lowest: compound 2; then compounds 3, 1 and 4 (each within the scatter of the next, the first and the last beyond it).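

Replacing 5-fluoropyridin-2-yl with 5-fluoropyridin-3-yl on the sulfonyl sulfur keeps the same atoms and changes only how the ring is joined, yet in this assay it gives a number 12 percentage points higher from compound 3 to compound 4 (beyond the scatter), so at this position the point of attachment alone can shift the read-out, and here the shift is upward rather than the loss that the earlier large steps might suggest. The new ring also stands well clear of 3-methylpyridin-2-yl, with a number 45 percentage points higher from compound 2 to compound 4 (beyond the scatter), whereas the exchange for 5-methoxypyridin-2-yl gives a number 4 percentage points higher from compound 1 to compound 4 (within the scatter), so those two compounds cannot be told apart here. Nothing available explains why the way the ring is joined matters in this series.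

As far as these compounds go, it remains open whether the fluoro group on the 5-fluoropyridin-3-yl ring is needed, and whether an amine or a carboxylic acid in its place would keep the inhibition. The read-out is also taken at a single dose and is not a potency, so compounds with numbers this high may still differ in ways it cannot show.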